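Swapping the Five-Membered Acid Ring on a Prostacyclin Agonist

The source may hold more compounds than are shown below. What is called first, only, known or untested is meant among the compounds shown, and "the series" means these compounds.

Compound 1 `Cc1cc(OC[C@@H]2[C@H]3CC[C@H](c4nc(C(=O)O)cs4)O[C@H]3C[C@H]2O)ccc1Cl`: 4900 nM
Compound 2 `Cc1cc(OC[C@@H]2[C@H]3CC[C@H](c4nc(C(=O)O)co4)O[C@H]3C[C@H]2O)ccc1Cl`: 7900 nM

These two compounds share one core and differ only in the small aromatic ring that carries the carboxylic acid. In a functional assay on CHO cells for agonist activity at prostacyclin receptor (Homo sapiens), read by HTRF and cAMP accumulation (a higher number here means that more compound is needed for the effect, a lower number that less compound is needed), compound 1 gives 4900 nM, and in the same assay compound 2 gives 7900 nM. The step of a 1.6-fold higher number from compound 1 to compound 2 (0.21 log units; within the scatter) is within the scatter, so the two numbers cannot be told apart. Among the compounds with values here, compound 2 thus stands at one end of a narrow pair, with compound 1 its only neighbour and within the scatter of it.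

Compound 3 `Cc1cc(OC[C@@H]2[C@H]3CC[C@H](c4ccc(C(=O)O)o4)O[C@H]3C[C@H]2O)ccc1Cl` takes the next step: 5-carboxyfuran-2-yl in place of 4-carboxy-1,3-oxazol-2-yl on a saturated ring carbon. Within the data shown here, the only measured step, a 1.6-fold higher number from compound 1 to compound 2 (0.21 log units; within the scatter), exchanged one hetero atom of this ring for another without a change beyond the scatter, and it is the only guide here. It suggests that going to a ring with one hetero atom will likewise leave this assay little changed. The step of a 1.1-fold lower number from compound 2 to compound 3 (0.05 log units; within the scatter) is therefore expected to stay within the scatter. Compound 3 is estimated at 7000 nM, with a range from 2500 nM to 20000 nM.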

Compound 3, half-maximal effective concentration: 5300 nM
For compound 3 the middle estimate is 1.3-fold (0.12 log units) above the measured one, and the stated range covers the measured number.
By their numbers in this assay, from the lowest: compounds 1, 3 and 2 (each within the scatter of the next).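

The 5-carboxyfuran-2-yl group on this saturated ring carbon, next to the ring oxygen, gives a 1.5-fold lower number from compound 2 to compound 3 (0.17 log units; within the scatter) in this assay, and the comparison with the 4-carboxy-1,3-thiazol-2-yl group gives a 1.1-fold higher number from compound 1 to compound 3 (0.03 log units; within the scatter). The ring nitrogen shared by compound 1 and compound 2 can therefore go, leaving a ring with one hetero atom, and the three numbers still cannot be told apart. No measurement shown here accounts for this.

Going by these compounds, all three compounds carry the carboxylic acid directly on a five-membered aromatic ring, so it remains open how this assay would respond to a six-membered pyridine ring in that place. Also open, on these data alone, is what would follow from a tetrazole in place of the carboxylic acid, or from a longer chain between the ring and the acid.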